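Trifluoromethyl for methyl on the benzyl of compound 1

The source may hold more compounds than are shown below. What is called first, only, known or untested is meant among the compounds shown, and "the series" means these compounds.

The three measured compounds share one core and differ only in the group on the aromatic carbon of one benzyl. In a functional assay on the whole organism (strain C57Bl/6) for inhibition, with Mus musculus as the target, with a stated time of 180 min, at 48 degrees C (on this read-out higher numbers stand for an effect only at larger amounts of compound and lower numbers for an effect already at smaller amounts), compound 1 `COc1ccc(Cn2c(=O)nc(NCCNC(=N)N)n(Cc3ccc(C)cc3)c2=O)cc1` gives 0.0045 nM, the second highest of the three numbers. Compound 2 `COc1ccc(Cn2c(NCCNC(=N)N)nc(=O)n(Cc3ccc(Cl)cc3)c2=O)cc1` gives 0.004 nM, and compound 3 `CCc1ccc(Cn2c(=O)nc(NCCNC(=N)N)n(Cc3ccc(OC)cc3)c2=O)cc1` gives 0.0058 nM; both lie within the scatter of compound 1, so no order among the three can be read from them. Going by the values given here, the only step between compounds that differ in one place is a 1.5-fold higher number from compound 2 to compound 3 (0.16 log units; within the scatter), an exchange at the same aromatic carbon that changed the number by less than the scatter.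

Compound 4 `COc1ccc(Cn2c(=O)nc(NCCNC(=N)N)n(Cc3ccc(C(F)(F)F)cc3)c2=O)cc1` is not yet measured. It differs from compound 1 in one place: trifluoromethyl in place of methyl on an aromatic carbon. The exchange at this aromatic carbon in the step from compound 2 to compound 3 did not move the number beyond the scatter, and the values of compound 1 and compound 2 show the same for methyl against chloro. Among the compounds with values here, nothing among the measured compounds points to a step beyond the scatter, so the number for compound 4 is expected to stay close to that of compound 1, as a 1.1-fold higher number from compound 1 to compound 4 (0.05 log units; within the scatter). Compound 4 is therefore estimated at 0.005 nM, with a range from 0.002 nM to 0.013 nM.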

Compound 4, half-maximal effective concentration: 0.048 nM
Compound 4: the middle estimate sits 9.6-fold (0.98 log units) below what was measured; measured number above the stated range.
By their numbers in this assay, from the lowest: compounds 2, 1 and 3 (each within the scatter of the next); then compound 4.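

In this assay, going by these compounds alone, trifluoromethyl in place of methyl gives an 11-fold higher number from compound 1 to compound 4 (1.03 log units; beyond the scatter) on this aromatic carbon, the first exchange here to move the number beyond the scatter. The position is therefore not indifferent to what it carries: methyl, chloro and ethyl leave the numbers within the scatter of each other, whereas with trifluoromethyl an effect appears only at larger amounts of compound, and of the four numbers that of compound 4 is the highest. No measurement of any property of these compounds is at hand to account for this step.

The compounds shown leave open whether a single fluorine, a nitrile, an amine or a carboxylic acid on this aromatic carbon would stay with methyl, chloro and ethyl or follow trifluoromethyl, and so whether the step belongs to trifluoromethyl alone. They also leave open whether trifluoromethyl in place of the methoxy group on the other benzyl would give a step of similar size, which would show whether the change is tied to this position.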